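The compounds below may be only part of what the source reports. "The series", "measured", "known", "first", "only" and "open" are said of these compounds alone.

Measured compounds:
- Compound 1, `COc1ccc(N(C)c2nc(Cl)nc3c2ncn3Cc2cc(OC)c(OC)c(OC)c2)cc1`: 3000 nM
- Compound 2, `COc1cc(Cn2cnc3c(Cl)ncnc32)cc(OC)c1OC`: > 100000 nM

Compound 1 was tested in a functional assay on SH-SY5Y cells (Homo sapiens) for antiproliferative activity, read by MTT assay, with a stated time of 48 h (a higher number here means a weaker inhibitor of growth, a lower number a stronger inhibitor of growth), and gives 3000 nM. Compound 2 stands differently: in this assay compound 2 reaches only a limit of the assay, > 100000 nM, and no number. Of the two values shown, one therefore sits at the bound described by the limit of > 100000 nM in this assay, at which 1 of the 2 values shown sits, so compound 2 marks the weak end of what has been measured here.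

The step from compound 2 to compound 3 brings in `COc1cc(Cn2cnc3c(Cl)nc(Cl)nc32)cc(OC)c1OC`, which has not yet been tested. The change is chloro in place of hydrogen on an aromatic carbon. Within the data shown here, compound 3 carries two chloro groups on the core of compound 2, and no measured pair isolates this change. In this assay a step toward stronger growth inhibition is expected, but a modest one, since compound 3 lacks the substituted amine that compound 1 carries. Compound 3 is estimated at 50000 nM, within 10000 nM to 200000 nM, which means an expected step of an at least 2.0-fold lower number from compound 2 to compound 3 (0.30 log units; that floor lies within the scatter).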

Compound 3, concentration for 50% growth inhibition: 9600 nM
Compound 3: middle estimate off by 5.2-fold (0.72 log units), on the high side; the measured number lies below the stated range.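

In this assay, a single chloro on an aromatic carbon between two ring nitrogen atoms brings growth inhibition into the measurable range, with an at least 10-fold lower number from compound 2 to compound 3 (1.01 log units; beyond the scatter). Going by these compounds, the true size of this step remains unknown because compound 2 stands at a limit of the assay: the limit of > 100000 nM in this assay, at which 1 of the 3 values shown sits. The exchange of (4-methoxyphenyl)(methyl)amino for chloro on an aromatic carbon gives only a modest loss, with a 3.2-fold higher number from compound 1 to compound 3 (0.51 log units; beyond the scatter), so the larger amino group is not required for measurable growth inhibition.

The compounds shown leave open whether the gain is specific to chloro or would also appear with a fluoro or a primary amine at that position between the two ring nitrogen atoms. They also leave open what the three methoxy groups on the benzyl group contribute, since all three compounds carry them.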